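The compounds below may be only part of what the source reports. "The series", "measured", "known", "first", "only" and "open" are said of these compounds alone.

Of the compounds shown here, three have been measured in an ADME assay on BaF3 cells (Mus musculus) for cytotoxicity; on this read-out higher numbers stand for an effect only at larger amounts of compound and lower numbers for an effect already at smaller amounts. Compound 1, `COC(=O)c1cc2c(Nc3ccc(OC(F)(F)F)cc3)ncnc2s1`, returns > 10000 nM, which is a limit of this assay rather than a number. Compound 2, `NC(=O)c1cccc(Oc2cc(Nc3ccc(OC(F)(F)F)cc3)ncn2)c1`, gives > 10000 nM, again a limit. Compound 3, `CS(=O)(=O)c1cccc(-c2cc(Nc3ccc(OC(F)(F)F)cc3)ncn2)c1`, gives > 10000 nM, also a limit. All three sit at the limit of > 10000 nM in this assay, at which 3 of the 3 values shown sit, so nothing separates them, and compound 1 stands simply at that limit alongside the other two, with no number of its own.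

Compound 4, `O=C(c1cc2c(Nc3ccc(OC(F)(F)F)cc3)ncnc2s1)N1CCC(O)CC1`, has not yet been measured in this assay. It differs from compound 1 by 4-hydroxypiperidin-1-yl in place of methoxy on a carbonyl carbon. For the measured compounds named here, no measured pair shows a change of this kind, so the size of the step cannot be read from the data and can only be expected. Since every value shown sits at the limit of > 10000 nM in this assay, at which 3 of the 3 values shown sit, the expectation is that the step that the limit leaves unreadable from compound 1 to compound 4 is none beyond the scatter. Compound 4 is therefore estimated at 15000 nM, with a range from 5000 nM to 50000 nM, and the result is most likely to be reported once more only as a limit.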

Compound 4, half-maximal effective concentration: > 10000 nM
Compound 4: only a limit was reported (the forecaster's own chance of this, stated with the estimate: 85%); the middle value lies beyond the limit too.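

In this assay compound 4 gives > 10000 nM, which is a limit and not a number. Compound 1 is also reported only as a limit, so no step can be read between compound 1 and compound 4: the limit of > 10000 nM in this assay, at which 4 of the 4 values shown sit.

The compounds shown leave open whether any structural change here would yield an actual number in this assay.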